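Fluoro to methyl on a well-tolerated compound

The source may hold more compounds than are shown below. What is called first, only, known or untested is meant among the compounds shown, and "the series" means these compounds.

Compound 3 `O=C1/C(=C/c2ccc(F)cc2)CCC/C1=C\c1ccc([N+](=O)[O-])cc1` is the starting point, and it was tested in an ADME assay on HPLF cells (Homo sapiens) for cytotoxicity, with a stated time of 24 h; a lower number here means that less compound is tolerated, a higher number that more compound is tolerated. Compound 3 gives > 400000 nM, which is a limit of the assay and not a number. Compound 1 `CN(C)c1ccc(/C=C2\CCC/C(=C\c3ccccc3[N+](=O)[O-])C2=O)cc1` gives > 400000 nM, which is also a limit. The picture so far is the limit of > 400000 nM in this assay, at which 3 of the 3 values shown sit.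

Compound 4 `Cc1ccc(/C=C2\CCC/C(=C\c3ccc([N+](=O)[O-])cc3)C2=O)cc1` differs from compound 3 in one place: methyl in place of fluoro on an aromatic carbon, para to a large group (methyl in place of fluoro on an aromatic carbon). Within the data shown here, no pair of measured compounds shows the size of this swap directly. The closest guide is compound 2 `Cc1ccc(/C=C2\CCC/C(=C\c3cccc([N+](=O)[O-])c3)C2=O)cc1`, which also carries a 4-methylphenyl and gives > 400000 nM, again a limit.

On that basis, no change beyond the usual scatter is expected in this assay, and another limit is the likeliest result. The estimated step is a number no higher from compound 3 to compound 4 (the limit leaves the size open). Compound 4 is estimated at 400000 nM, with an expected range from 200000 nM to 800000 nM.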

Compound 4, half-maximal cytotoxic concentration: 348000 nM
Beside the measured number, compound 4's estimate is 1.1-fold (0.06 log units) above it; low and high end bracket the measured number.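

In this assay, among these compounds, compound 4 gives 348000 nM, the first real number in this set rather than a limit. Going from 4-fluorophenyl to 4-methylphenyl gives an at least 1.1-fold lower number from compound 3 to compound 4 (0.06 log units; that floor lies within the scatter), so this swap at this position cannot be told apart from the variation between repeat measurements, and the true size of the step stays unknown. Even so, one number now marks a point close to where the assay stops reading, while most of the set remains at that ceiling: the limit of > 400000 nM in this assay, at which 3 of the 4 values shown sit.

From the compounds shown here alone, how a carboxylic acid or a longer chain such as propyl would read at this same position remains open. So does whether such a group would give a value clearly beyond the scatter, which neither fluoro nor methyl shows.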